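The source may hold more compounds than are shown below. What is called first, only, known or untested is meant among the compounds shown, and "the series" means these compounds.

Of the compounds shown here, three of a shared core have been tested in an ADME assay on MT4 cells (Homo sapiens) for cytotoxicity, read by MTT assay, with a stated time of 5 days; a lower number here means that less compound is tolerated, a higher number that more compound is tolerated. Compound 1 `O=[N+]([O-])c1ccc(-c2nnc(-c3cccnc3)n2Nc2nc3ccc(Cl)cc3s2)cc1` gives 53.7 ug/mL. Compound 2 `Clc1ccc(-c2nnc(-c3cccnc3)n2Nc2nc3ccc(Br)cc3s2)cc1` gives 29.6 ug/mL. Compound 3 `Cc1ccc2nc(Nn3c(-c4ccc(Cl)cc4)nnc3-c3cccnc3)sc2c1` gives 75.5 ug/mL, the highest of the three numbers: compound 1 sits within the scatter of it, while compound 2 lies beyond the scatter below it.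

Compound 4 `Clc1ccc(-c2nnc(-c3cccnc3)n2Nc2nc3ccc(Cl)cc3s2)cc1` differs from compound 3 by chloro in place of methyl on an aromatic carbon. Among the measured compounds shown here, only one measured step bears on this position: a 2.6-fold higher number from compound 2 to compound 3 (0.41 log units; beyond the scatter), a bromo to methyl exchange. Compound 4 reverses the direction of that step, going from methyl back to a halogen, though to chloro rather than bromo. Compound 1, which already carries chloro at this position, shows a number within the scatter of compound 3, but compound 1 also differs from compounds 2 and 3 elsewhere, so no clean step can be read from it. On balance a modest move toward a lower number is expected, of the order of a 1.7-fold lower number from compound 3 to compound 4 (0.22 log units; within the scatter), possibly no further than the edge of the scatter. Compound 4 is therefore estimated at 45 ug/mL in this assay, with a range from 25 ug/mL to 80 ug/mL.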

Compound 4, half-maximal cytotoxic concentration: 54.3 ug/mL
The estimate for compound 4 lay 1.2-fold (0.08 log units) below the measured number; low and high end bracket the measured number.
By their numbers in this assay, from the lowest: compounds 2, 1, 4 and 3 (each within the scatter of the next, the first and the last beyond it).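

In this assay, the chloro compound can be set against both earlier groups at this aromatic carbon of the fused system: chloro in place of methyl gives a small step (a 1.4-fold lower number from compound 3 to compound 4 (0.14 log units; within the scatter)), and chloro in place of bromo gives another (a 1.8-fold higher number from compound 2 to compound 4 (0.26 log units; within the scatter)). Both steps lie within the scatter, so chloro cannot be told apart from either group, even though the bromo and methyl compounds remain separated by a step beyond the scatter (a 2.6-fold higher number from compound 2 to compound 3 (0.41 log units; beyond the scatter)); that single step therefore gives no general halogen-to-methyl trend at this position. Among the compounds shown here, compound 4 also supplies the first clean reading at the site that carries nitro in compound 1, where chloro in place of nitro leaves the number effectively unchanged (a 1.0-fold higher number from compound 1 to compound 4 (0.00 log units; within the scatter)).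

Nothing available explains any of these numbers. With only methyl, chloro and bromo shown at the first site and only nitro and chloro at the second, it remains open whether an amine, a methoxy group or a carboxylic acid at either site would keep the number within the same range.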